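The source may hold more compounds than are shown below. What is called first, only, known or untested is meant among the compounds shown, and "the series" means these compounds.

Compound 1 `CN1CCN(c2ccc(Nc3ncc4c(n3)N(C3CCCC3)CC(=O)N4C)nc2)CC1` and compound 2 `CN1C(=O)CN(C2CCCC2)c2nc(Nc3ccc(N4CCCCC4)cn3)ncc21` share one core and differ at a single point: piperidin-1-yl in place of 4-methylpiperazin-1-yl on an aromatic carbon. In a functional assay on HCT-116 cells (Homo sapiens) for inhibition, read by MTT assay, with a stated time of 48 h (a higher number here means a weaker inhibitor, a lower number a stronger inhibitor), compound 1 gives 9730 nM, and compound 2 gives 3890 nM, so that a 2.5-fold lower number from compound 1 to compound 2 (0.40 log units; beyond the scatter). Compound 3 `CCN1C(=O)CN(C2CCCC2)c2nc(Nc3ccc(N4CCN(C)CC4)cc3)ncc21` has another core; how it differs from the core of compound 1 is not broken down here. In this assay compound 3 gives 7960 nM. Compound 4 `CCN1C(=O)CN(C2CCCC2)c2nc(Nc3ccc(N4CCCCC4)cc3)ncc21` is not yet measured and differs from compound 3 by piperidin-1-yl in place of 4-methylpiperazin-1-yl on an aromatic carbon. This is the same kind of change as that from compound 1 to compound 2, not the same change: there the ring holding the group had one nitrogen and the group sat two atoms from the ring nitrogen, whereas here the ring is of carbon only. The step from compound 3 to compound 4 is expected to be a 2.5-fold lower number from compound 3 to compound 4 (0.40 log units; beyond the scatter). That expectation rests on compound 2 and the measured step of a 2.5-fold lower number from compound 1 to compound 2 (0.40 log units; beyond the scatter). Compound 4 is estimated at 3200 nM, likely between 1500 nM and 7000 nM.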

Compound 4, half-maximal inhibitory concentration: 5470 nM
For compound 4 the middle estimate is 1.7-fold (0.23 log units) below the measured one, within the range that was stated.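

In this assay, piperidin-1-yl in place of 4-methylpiperazin-1-yl on the second core gives a 1.5-fold lower number from compound 3 to compound 4 (0.16 log units; within the scatter), so this step alone cannot be told apart from the spread of repeated measurements. Set beside the earlier step, it gives no sign that the change behaves differently on the two cores: the same change on two cores in this assay, a 2.5-fold lower number (0.40 log units; beyond the scatter) from compound 1 to compound 2 and a 1.5-fold lower number (0.16 log units; within the scatter) from compound 3 to compound 4, 1.7-fold (0.24 log units) apart, within the scatter of two such steps. Among these compounds, this rests on only two pairs, and it shows neither a real gain on the second core nor that the result would hold on any further core.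

The compounds shown leave open how other groups at this place would behave, such as morpholin-4-yl, a simple primary amine or a carboxylic acid.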